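Acetamido removal on the aminophenyl arm of the shared core

The compounds below may be only part of what the source reports. "The series", "measured", "known", "first", "only" and "open" are said of these compounds alone.

Measured so far in a functional assay on MCF7 cells (Homo sapiens) for cytotoxicity, read by MTT assay, with a stated time of 48 h; a lower number here means a stronger inhibitor, a higher number a weaker inhibitor:
- compound 1 `COc1ccc(N)cc1-c1cnc2[nH]cc(-c3ccncc3)c2c1`: compound 1 gives 5400 nM.
- compound 2 `CC(=O)Nc1cc(N)cc(-c2cnc3[nH]cc(-c4ccncc4)c3c2)c1`: compound 2 gives > 30000 nM, which is a limit of the assay and not a number.

Compound 2 therefore stands at the edge of what this assay can report: the limit of > 30000 nM in this assay, at which 1 of the 2 values shown sits. Among the measured compounds shown here, of the two measured compounds, only compound 1 has a defined value, and the two differ in more than one place, so no single step between them can be read off.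

For the measured compounds named here, the next compound, compound 3 `Nc1cccc(-c2cnc3[nH]cc(-c4ccncc4)c3c2)c1`, keeps the amino group on the phenyl ring and the rest of the core of compound 2 unchanged; the one change is hydrogen in place of acetamido on an aromatic carbon.

With compound 2 known only as a limit, the size of the step is uncertain in both directions. Compound 1, which also carries an amino group on that ring, gives 5400 nM, and the smaller compound 3 is expected to fall between that value and the edge of what this assay can report. The expected step is an at least 2.5-fold lower number from compound 2 to compound 3 (0.39 log units; beyond the scatter). For compound 3 the estimate is 12000 nM, with a range from 3500 nM to 30000 nM.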

Compound 3, half-maximal inhibitory concentration: 2300 nM
Compound 3: the middle estimate sits 5.2-fold (0.72 log units) above what was measured; the whole stated range lies above it.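

In this assay, hydrogen in place of acetamido, on an aromatic carbon meta to an amino group, gives an at least 13-fold lower number from compound 2 to compound 3 (1.11 log units; beyond the scatter), so the acetamido group at this position goes with a loss of cytotoxic effect that the bare carbon does not show. The size of this step is only a bound, since compound 2 gives no defined number: the limit of > 30000 nM in this assay, at which 1 of the 3 values shown sits. Hydrogen in place of methoxy gives a 2.3-fold lower number from compound 1 to compound 3 (0.37 log units; beyond the scatter), a modest step, so compound 3, which keeps only the amino group on the phenyl ring, now has the lowest number in this short set, and neither acetamido nor methoxy improves on hydrogen.

The compounds shown leave open whether the acetamido effect holds for smaller groups on the same carbon, such as fluorine, methyl or hydroxyl, or for a charged group such as a carboxylic acid. They also leave open how much the amino group itself contributes, which a compound with a hydroxyl group or a methyl group in its place would address.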